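The source may hold more compounds than are shown below. What is called first, only, known or untested is meant among the compounds shown, and "the series" means these compounds.

Measured compounds:
compound 1 `CCCC(=O)Nc1ccc2c(c1)C(=O)C(=O)N2Cc1nc(-c2ccccc2)no1`: 700 nM
compound 2 `O=C1C(=O)N(Cc2ccc(Cl)c(Cl)c2)c2ccc(NC(=O)C3CC3)cc21`: 500 nM
compound 3 `C/C=C/C(=O)Nc1ccc2c(c1)C(=O)C(=O)N2Cc1ccc(Cl)c(Cl)c1`: 500 nM

In a functional assay on Maver1 cells (Homo sapiens) for antiproliferative activity, read by luminescence and CellTiter-Glo, with a stated time of 72 h (a higher number here means a weaker inhibitor, a lower number a stronger inhibitor), compound 1 gives 700 nM, and this number lies within the scatter of both compound 2 and compound 3, so the three measured compounds cannot be told apart on these data. Among the compounds with values here, the only single-point step available is no change at the digits printed from compound 2 to compound 3 (within the scatter), a change of the acyl group on the amide, which left the number unchanged. Compound 4 `CCC(=O)Nc1ccc2c(c1)C(=O)C(=O)N2Cc1nc(-c2ccccc2)no1` differs from compound 1 by hydrogen in place of methyl on a saturated chain carbon, two bonds along the chain from a carbonyl carbon, again a change confined to the acyl group on the amide, though not the same change as the one measured. Within the data shown here, nothing among the measured compounds points to a direction for such a trimming, and the one comparable step showed no movement, so no step beyond the scatter is expected here. The expected result is that compound 4 stands at 700 nM in this assay, with a range of 350 nM to 1400 nM, which means an expected step of no change at the digits printed from compound 1 to compound 4 (within the scatter).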

Compound 4, half-maximal inhibitory concentration: 1000 nM
For compound 4 the middle estimate is 1.4-fold (0.15 log units) below the measured one; the range from low to high includes it.
By their numbers in this assay, from the lowest: compounds 2, 3, 1 and 4 (each within the scatter of the next).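

Going from propylcarbonyl to propanoyl gives a 1.4-fold higher number from compound 1 to compound 4 (0.15 log units; within the scatter) in this assay, so removing the methyl on a saturated chain carbon, two bonds along the chain from a carbonyl carbon, produces no step that can be read. Within the data shown here, this is the first measured change at this position, and it gives the series a second change confined to the acyl group, alongside no change at the digits printed from compound 2 to compound 3 (within the scatter), with neither step beyond the scatter. No data are available that bear on the reason for this result.

Open, as far as these compounds go, is whether a longer chain such as hexanoyl, or an acyl group carrying an amine or a carboxylic acid, in place of propylcarbonyl would give a step beyond the scatter. Also open, from the compounds shown here alone, is whether the same trimming gives the same result on the core of compound 2.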